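The source may hold more compounds than are shown below. What is called first, only, known or untested is meant among the compounds shown, and "the series" means these compounds.

Series notes, step from compound 1 to compound 4.

Among the measured compounds shown here, compound 1 `COc1ccc(C(=O)/C(=C/c2ccc(Cl)cc2Cl)CCOC(C)=O)cc1` is the only member of the shared core with a number in a functional assay on MCF7 cells (Homo sapiens) for inhibition, read by XTT assay, with a stated time of 48 h; a lower number here means a stronger inhibitor, a higher number a weaker inhibitor: compound 1 gives 83400 nM. Compound 2 `COc1ccc(C(=O)/C(=C/c2ccc([N+](=O)[O-])cc2)CCOC(C)=O)cc1` gives > 100000 nM in this assay, and that value is a limit of the assay. Compound 3 `COc1ccc(C(=O)/C(=C/c2ccc(Cl)cc2)CCOC(C)=O)cc1` likewise gives > 100000 nM in this assay, again a limit. Both limits are summed up in the limit of > 100000 nM in this assay, at which 2 of the 3 values shown sit. The step of an at least 1.1-fold higher number from compound 1 to compound 2 (0.07 log units; that floor lies within the scatter) and the step of an at least 1.1-fold higher number from compound 1 to compound 3 (0.07 log units; that floor lies within the scatter) are therefore only floors, and the step that the two limits leave unreadable from compound 2 to compound 3 is unreadable.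

Compound 4 `COc1ccc(C(=O)/C(=C/c2ccc(Cl)cc2Cl)CC(C)OC(C)=O)cc1` differs from compound 1 by methyl in place of hydrogen on a saturated chain carbon bound to an oxygen next to a carbonyl group and a saturated chain carbon, the change reading as 2-acetoxyethyl to 2-acetoxypropyl. For the measured compounds named here, none of the measured steps touches that chain; all three vary the aryl group on the double-bonded chain carbon, and none gives a readable size. No basis for a step beyond the scatter in this assay exists, so the expected step is a 1.0-fold lower number from compound 1 to compound 4 (0.00 log units; within the scatter). Compound 4 is thus estimated at 83000 nM in this assay, within 30000 nM to 200000 nM.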

Compound 4, half-maximal inhibitory concentration: > 100000 nM
Compound 4: a limit, no number (the forecaster's own chance of this, stated with the estimate: 35%); middle value at least 1.2-fold (0.08 log units) away from the limit.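

In this assay compound 4 gives > 100000 nM, which is a limit of the assay and not a number. This is the only step shown on the chain rather than on the aryl group, and methyl in place of hydrogen on this saturated chain carbon yields only a floor, an at least 1.1-fold higher number from compound 1 to compound 4 (0.07 log units; that floor lies within the scatter), so the true size of the change from 2-acetoxyethyl to 2-acetoxypropyl cannot be read. Compound 1 remains the only member of the series with a number, and the limit now holds most of the values: the limit of > 100000 nM in this assay, at which 3 of the 4 values shown sit.

Whether any change on this chain can give a readable number stays open, since a hydroxyl group or an amine in place of the acetoxy group lies outside the compounds shown. As far as these compounds go, how far compound 4 lies beyond its floor also stays open.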